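Methoxycarbonyl in Place of Hydroxymethyl: Outlook for Compound 3

A few compounds are considered here, and "the series" means these few. Any claim that something is new, unique, unknown or untested is made for them only; others in the source may bear on it.

Of the compounds shown here, two have been measured in a functional assay on MCF7 cells (Homo sapiens) for cytotoxicity, read by MTT assay; on this read-out higher numbers stand for weaker inhibition and lower numbers for stronger inhibition. Compound 1 `C=C1C(=O)O[C@H]2C/C(C)=C/[C@@H](O)C/C(C)=C/CC/C(C)=C/C[C@H]12` gives > 5 ug/mL, a limit rather than a number. Compound 2 `C=C1C(=O)O[C@H]2/C=C(\C)CC/C=C(\CO)CC/C=C(\C)CC[C@@H]12` likewise gives > 5 ug/mL, again a limit. For the measured compounds named here, compound 2 therefore stands at the limit, as does the only other value shown: the limit of > 5 ug/mL in this assay, at which 2 of the 2 values shown sit, is all that these two measurements offer, and no step between measured compounds can be drawn from them. Compound 3 `C=C1C(=O)O[C@H]2/C=C(\C)CC/C=C(\C(=O)OC)CC/C=C(\C)CC[C@@H]12` differs from compound 2 in one place: methoxycarbonyl in place of hydroxymethyl on a double-bonded ring carbon. Going by the values given here, no measured step resembles this change, so the size of the step from compound 2 to compound 3 cannot be read off the data. The estimate of a step that the limit leaves unreadable from compound 2 to compound 3 expresses the expectation of no step beyond the usual scatter. Compound 3 is accordingly expected to give about 8 ug/mL in this assay, within a range of 3 ug/mL to 25 ug/mL, most likely reported once more only as a limit.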

Compound 3, half-maximal inhibitory concentration: > 5 ug/mL
Compound 3 ended at the assay's limit; the forecaster's own chance of this, stated with the estimate: 70%; the middle value does not contradict the limit.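

No step can be read from compound 2 to compound 3, as both remain limits rather than numbers in this assay: the limit of > 5 ug/mL in this assay, at which 3 of the 3 values shown sit.

The compounds shown leave open whether methoxycarbonyl in place of hydroxymethyl changes the read-out at all, and how compound 1, compound 2 and compound 3 rank against one another.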